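Trimming a tert-Butyl: Cytotoxicity Expected to Hold Steady

The source may hold more compounds than are shown below. What is called first, only, known or untested is meant among the compounds shown, and "the series" means these compounds.

Compound 1 `CC(C)(C)c1ccc(OCCCCCn2ccc(=O)[nH]c2=O)cc1` carries a tert-butyl group on its aromatic ring. For the measured compounds named here, in an ADME assay on HEL cells (Homo sapiens) for cytotoxicity (a higher number here means that more compound is tolerated, a lower number that less compound is tolerated), compound 1 gives 40000 nM, and this is the only plain number among the two results so far, so it stands alone rather than high or low relative to anything measured. Compound 2 `O=c1ccn(CCCCCCCCOc2ccc(Br)cc2)c(=O)[nH]1` is the other compound tested. In this assay compound 2 gives > 100000 nM, which is a limit of the assay and not a number (the limit of > 100000 nM in this assay, at which 1 of the 2 values shown sits). Going by the values given here, no two measured compounds differ in a single place, so no measured step is available to lean on.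

Compound 3 `CC(C)c1ccc(OCCCCCn2ccc(=O)[nH]c2=O)cc1` differs from compound 1 by hydrogen in place of methyl on a saturated chain carbon bound to an aromatic carbon and two saturated chain carbons. Removing one methyl in this way is a small change to a molecule of this size, and the step of a 1.1-fold higher number from compound 1 to compound 3 (0.05 log units; within the scatter) is expected to be small, in no particular direction, and of a size that the usual scatter of repeated measurements would not separate. Compound 3 is therefore estimated at 45000 nM, with a plausible range from 18000 nM to 110000 nM.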

Compound 3, half-maximal cytotoxic concentration: > 100000 nM
Compound 3: no number, only a limit; the forecaster's own chance of this, stated with the estimate: 35%; middle value at least 2.2-fold (0.34 log units) away from the limit.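

For the compounds shown here, changing tert-butyl to isopropyl gives an at least 2.5-fold higher number from compound 1 to compound 3 (0.39 log units; beyond the scatter) and this is the first change at a single place in this set that can be read at all. It shows that removing just one methyl from the tert-butyl group, on a saturated chain carbon bound to an aromatic carbon and two saturated chain carbons, is enough to move the result beyond the usual scatter, towards more compound being tolerated. In this assay compound 3 gives > 100000 nM and this is a limit of the assay, not a number, so the step has a lower bound and no known full size, because the reading stops at the same ceiling that other compounds reach: the limit of > 100000 nM in this assay, at which 2 of the 3 values shown sit.

The compounds shown leave open whether a plain methyl, an amine or a carboxylic acid in place of the tert-butyl would give a reading that can be told apart from this ceiling. They also leave open whether the same change from tert-butyl to isopropyl would have a similar effect with a longer chain in the molecule.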